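The source may hold more compounds than are shown below. What is called first, only, known or untested is meant among the compounds shown, and "the series" means these compounds.

Three compounds have been tested in a functional assay on HCT-116 cells (Homo sapiens) for inhibition, read by CCK-8 assay, with a stated time of 72 h, tested at 2 uM (a higher number here means more inhibition of growth at the concentration tested, a lower number less inhibition of growth), so far:

Compound 1 `COc1ccc(SCc2ccc(/C=C/C(=O)Nc3ccccc3N)cc2)cc1OC` gives 12.9%
Compound 2 `CCc1ccc(SCc2ccc(/C=C/C(=O)Nc3ccccc3N)cc2)cc1` gives 3.29%
Compound 3 `CC(C)(C)c1ccc(SCc2ccc(C(=O)Nc3ccccc3N)cc2)cc1` gives 4.81%

All three numbers lie within the usual scatter of one another, so repeat measurements could not reliably tell them apart. Compound 2 therefore has no distinct rank, and it belongs to a group that shows only slight growth inhibition at the concentration tested.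

The next compound is compound 4 `Nc1ccccc1NC(=O)/C=C/c1ccc(CSCCc2ccccc2)cc1`, which has not yet been measured. The change from compound 2 is phenethyl in place of 4-ethylphenyl on a sulfur and consists of phenethyl in place of 4-ethylphenyl on a sulfur. The two compounds contain the same atoms, joined differently.

Going by the values given here, only one measured step bears on this change. It concerns the same place on the sulfur, and the swap of groups there gives a number 9.6 percentage points lower from compound 1 to compound 2 (within the scatter) as its result. That step stays within the scatter, although a single step is thin evidence. Among the compounds with values here, no single-place step has been measured for compound 3.

On this basis, no change beyond the scatter is expected, and the estimated move is a number 3.7 percentage points higher from compound 2 to compound 4 (within the scatter) in size. For compound 4 the expected value is 7% with an estimated range from 0% to 20% as the likely span.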

Compound 4, percent growth inhibition at one concentration: 18%
The estimate for compound 4 lay 11 percentage points below the measured number, within the range that was stated.
By their numbers in this assay, from the lowest: compounds 2, 3, 1 and 4 (each within the scatter of the next, the first and the last beyond it).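

In this assay, going by these compounds alone, the swap on the sulfur gives a number 14.7 percentage points higher from compound 2 to compound 4 (beyond the scatter), the first step at this position to pass the usual scatter, and it comes from two groups made of the same atoms joined differently, so the way those atoms are arranged on the sulfur can alter the read-out even though their number and kind stay the same. The other new step, a number 5.1 percentage points higher from compound 1 to compound 4 (within the scatter), stays within the scatter, so the phenethyl compound stands apart from the 4-ethylphenyl compound but cannot be told apart from the 3,4-dimethoxyphenyl compound, and the gain is modest. No measurement shown here explains why the phenethyl group differs from the 4-ethylphenyl group.

The compounds shown leave open how the length of the chain between the sulfur and the ring matters, which a benzyl group or a 3-phenylpropyl group on the same sulfur could test. They also leave open whether an amine or a carboxylic acid on the phenethyl ring would shift the number further.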